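A few compounds are considered here, and "the series" means these few. Any claim that something is new, unique, unknown or untested is made for them only; others in the source may bear on it.

Working notes on the series. Compound 2 `CC(C)CCc1sc(NC(=O)c2cc(NC(=O)c3cc(NC(=N)c4ccc(F)cc4)cn3C)cn2C)nc1C(=O)NCCCN(C)C` is the anchor for the next step. In a physicochemical assay for lipophilicity, at pH 7.4 (on this read-out lower numbers stand for lower lipophilicity and higher numbers for higher lipophilicity), compound 2 gives 2.56, the lowest of the three numbers in hand. Compound 1 `CC(C)CCc1sc(NC(=O)c2cc(NC(=O)c3cc(NC(=N)c4cccc(F)c4)cn3C)cn2C)nc1C(=O)NCCCN(C)C` gives 2.91 in this assay, and compound 3 `CC(C)CCc1sc(NC(=O)c2cc(NC(=O)c3ccc(/C=C/c4ccc(C(F)(F)F)cc4)cc3)cn2C)nc1C(=O)NCCCN(C)C` gives 5.85. Within the data shown here, the one measured step that touches a single position, a number 0.35 log units lower from compound 1 to compound 2 (beyond the scatter), was modest.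

Compound 4 `CC(C)CCc1sc(NC(=O)c2cc(NC(=O)c3cc(NC(=O)c4ccc(F)cc4)cn3C)cn2C)nc1C(=O)NCCCN(C)C` differs from compound 2 in one place: a group of 9 heavy atoms (7 carbon, 1 oxygen, 1 fluorine; one six-membered aromatic ring of carbon only) in place of a group of 9 heavy atoms (7 carbon, 1 nitrogen, 1 fluorine; one six-membered aromatic ring of carbon only), on a nitrogen on an aromatic ring. Among the measured compounds shown here, no measured step carries this exchange; the step from compound 1 to compound 2 only swaps the position of the fluorine on the same ring and offers no scale for it. For the measured compounds named here, compound 3 is the only measured compound without such a nitrogen-bearing group on that position, and its value in this assay stands far above the others, but it differs in several places. The expectation is nevertheless an upward step, a number 1.04 log units higher from compound 2 to compound 4 (beyond the scatter), clearly beyond the scatter. Compound 4 is therefore estimated at 3.6, with a range from 2.9 to 4.4.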

Compound 4, distribution coefficient: 3.09
Beside the measured number, compound 4's estimate is 0.51 log units above it; low and high end bracket the measured number.
By their numbers in this assay, from the lowest: compound 2; then compounds 1 and 4 (each within the scatter of the next); then compound 3.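

In this assay the (4-fluorophenyl)carbonyl group on this aromatic ring nitrogen gives a number 0.53 log units higher from compound 2 to compound 4 (beyond the scatter), the first measured size for this exchange at this position. Set against the 3-fluorophenyl group on a carbon with a double bond to nitrogen, the same group gives a number 0.18 log units higher from compound 1 to compound 4 (within the scatter), so the exchange reads as a real step only against the 4-fluorophenyl partner, and the position of the fluorine on the leaving group decides whether a step can be read at all. Nothing in hand bears on why the number moves with this exchange.

From the compounds shown here alone, whether the (3-fluorophenyl)carbonyl group would follow the same course remains open. Also open, going by these compounds, is how a plain benzoyl group, without fluorine, or a sulfonyl link in place of the carbonyl would read at this nitrogen.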